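Ring-nitrogen methylation in a piperidinyl purine series

A few compounds are considered here, and "the series" means these few. Any claim that something is new, unique, unknown or untested is made for them only; others in the source may bear on it.

Measured so far in an assay on cells for displacement of a labelled ligand from adenosine receptor A2b (Homo sapiens), read by scintillation counting and radioligand binding, with a stated time of 30 min, tested at 10 uM; a higher number here means more inhibition at the concentration tested (going by the name of the read-out), a lower number less inhibition:
compound 1 `Cn1cnc2c(N3CCCCC3)nc(-c3cc(Cl)ccc3Cl)nc21` gives 31%
compound 3 `Clc1ccc(Cl)c(-c2nc(N3CCCCC3)c3nc[nH]c3n2)c1` gives 12.1%
compound 2 `Oc1cccc(-c2nc(N3CCCCC3)c3nc[nH]c3n2)c1` reaches only the limit of this assay, > 80%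

Among the compounds with values here, the one counted step so far is methyl in place of hydrogen on an aromatic nitrogen, which gives a number 18.9 percentage points higher from compound 3 to compound 1 (beyond the scatter) in this assay. How the core of compound 2 differs from that of compound 3 is not broken down here. Compound 4 `Cn1cnc2c(N3CCCCC3)nc(-c3cccc(O)c3)nc21` is the unmeasured partner of compound 2; it arises by methyl in place of hydrogen on an aromatic nitrogen, the same change as that from compound 3 to compound 1. Compound 2 already stands at the limit of > 80% in this assay, at which 1 of the 3 values shown sits, so the room left for a visible rise is limited.

Compound 4 is expected to remain high in this assay, with an estimate of 85% and a range from 60% to 100%. The step from compound 2 is expected to be a step that the limit leaves unreadable from compound 2 to compound 4, resting on the rise seen in a number 18.9 percentage points higher from compound 3 to compound 1 (beyond the scatter).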

Compound 4, a percentage reported as inhibition, at one concentration (the size of the read-out at that concentration, not a potency): 29.3%
For compound 4 the middle estimate is 55.7 percentage points above the measured one; measured number outside the range, below it.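

In this assay, methyl in place of hydrogen on an aromatic nitrogen gives a number at least 50.7 percentage points lower from compound 2 to compound 4 (beyond the scatter), against a number 18.9 percentage points higher from compound 3 to compound 1 (beyond the scatter), so the direction of this change does not carry from one core to the other: the same change on two cores in this assay, a number 18.9 percentage points higher (beyond the scatter) from compound 3 to compound 1 and a number at least 50.7 percentage points lower (beyond the scatter) from compound 2 to compound 4, at least 69.6 percentage points apart, beyond the scatter of two such steps

Compound 2 stands at a limit of the assay, > 80%, so its step is a bound and not an exact size.

Two pairs at one concentration do not show which feature of the core sets the direction, and once the methyl is present, 3-hydroxyphenyl in place of 2,5-dichlorophenyl gives a number 1.7 percentage points lower from compound 1 to compound 4 (within the scatter).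

Still open, going by these compounds, is which direction the change takes with an amine or a carboxylic acid on the aromatic carbon, and whether a longer chain on the aromatic nitrogen follows methyl.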